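The compounds below may be only part of what the source reports. "The series", "measured", "known", "first", "only" and "open" are said of these compounds alone.

Measured compounds:
- compound 1 `CS(=O)(=O)N1CCN(S(=O)(=O)CCCN2CCC(CNC(=O)c3cccc4c3OCCO4)CC2)CC1`: in an assay on isolated protein for inhibition of 5-hydroxytryptamine receptor 4 (Homo sapiens) (a lower number here means a stronger inhibitor, a higher number a weaker inhibitor), compound 1 gives 0.316 nM
- compound 2 `O=C(NCC1CCN(CCCS(=O)(=O)N2CCN(c3ccccn3)CC2)CC1)c1cccc2c1OCCO2`: in this assay compound 2 gives 0.251 nM

Among the compounds with values here, only two compounds have numbers, and they sit close together: the step of a 1.3-fold lower number from compound 1 to compound 2 (0.10 log units; within the scatter) is within the usual scatter, so compound 2 cannot be told apart from compound 1 on these data. Compound 3 `CC(=O)N1CCN(S(=O)(=O)CCCN2CCC(CNC(=O)c3cccc4c3OCCO4)CC2)CC1` has not yet been measured. It differs from compound 2 in one place: acetyl in place of pyridin-2-yl on an amine nitrogen in a ring. Within the data shown here, the one measured step that bears on this position, a 1.3-fold lower number from compound 1 to compound 2 (0.10 log units; within the scatter), exchanged the group on the same ring nitrogen and left the number essentially unchanged. On that basis the expected step of a 1.2-fold higher number from compound 2 to compound 3 (0.08 log units; within the scatter) is none beyond the scatter, with no clear direction. Compound 3 is therefore estimated to give about 0.3 nM in this assay, with a range from 0.12 nM to 0.8 nM.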

Compound 3, inhibition constant: 0.126 nM
Beside the measured number, compound 3's estimate is 2.4-fold (0.38 log units) above it; the range from low to high includes it.
By their numbers in this assay, from the lowest: compounds 3, 2 and 1 (each within the scatter of the next, the first and the last beyond it).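

Acetyl on the ring nitrogen gives the first step at this position that clears the usual scatter in this assay: acetyl in place of methylsulfonyl gives a 2.5-fold lower number from compound 1 to compound 3 (0.40 log units; beyond the scatter), a modest change. Acetyl in place of pyridin-2-yl gives a 2.0-fold lower number from compound 2 to compound 3 (0.30 log units; within the scatter), so compound 3 cannot be told apart from compound 2, even though 3 heavy atoms and no ring replace 6 heavy atoms and an aromatic ring. Nothing among the available data explains why acetyl and methylsulfonyl differ.

The three groups shown leave open how a bare hydrogen or a simple methyl on this ring nitrogen would compare. From the compounds shown here alone, it is also open whether a longer acyl group, such as propanoyl or benzoyl, would keep the number of compound 3.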